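A few compounds are considered here, and "the series" means these few. Any claim that something is new, unique, unknown or untested is made for them only; others in the source may bear on it.

Compound 1 (`CC(C)[C@@H](C[C@H]1SC(=O)NC1=O)c1ccc(-c2ccc3cccc(F)c3c2)[nH]c1=O`) was tested in an ADME assay on microsomes from liver (Rattus norvegicus) for metabolic stability (a lower number here means that the compound disappears faster, a higher number that the compound lasts longer), and gave 0.77 h. Among the compounds with values here, compound 3 (`CC(C)C(/C=C1\NC(=O)NC1=O)c1ccc(-c2ccc3cccc(F)c3c2)[nH]c1=O`) gave 1.46 h in this assay, a number that sits within the usual scatter of the one for compound 1, so the two cannot be told apart on these data. Compound 2 (`CC(C)(/C=C1\OC(=O)NC1=O)c1ccc(-c2ccc3cccc(F)c3c2)[nH]c1=O`) reached only a limit of the assay, > 3 h, and no number. That limit is recorded as the limit of > 3 h in this assay, at which 1 of the 3 values shown sits.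

Compound 4 (`CC(C)[C@H](C[C@H]1SC(=O)NC1=O)c1ccc(-c2ccc3cccc(F)c3c2)[nH]c1=O`) has not yet been measured. It differs from compound 1 in this way: the two compounds have the same atoms and bonds and differ only in configuration as drawn: 1 of 2 stereo elements differ; a stereocentre at a saturated chain carbon is drawn R in compound 1 and S in compound 4. Within the data shown here, no measured pair in this set shows what such a change does in this assay, so the size of the step can only be guessed. The account expects a step that stays within the scatter, in no settled direction, and describes the expected step as a 1.2-fold higher number from compound 1 to compound 4 (0.07 log units; within the scatter). On that basis compound 4 is estimated to give about 0.9 h in this assay, with a likely range from 0.4 h to 2 h.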

Compound 4, half-life: 0.143 h
Beside the measured number, compound 4's estimate is 6.3-fold (0.80 log units) above it, outside the stated range (below it).
By their numbers in this assay, from the lowest: compound 4; then compounds 1 and 3 (each within the scatter of the next). At a limit, above all of these: compound 2.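

Changing the stereocentre at a saturated chain carbon from R to S gives a 5.4-fold lower number from compound 1 to compound 4 (0.73 log units; beyond the scatter) in this assay, which shows that this position is sensitive to configuration alone. Within the data shown here, nothing enters or leaves, so the whole step goes with the configuration as drawn at that one carbon: the fact that compounds 1 and 4 differ only in the configuration as drawn The earlier compounds differed from each other in more than one place, so they could not separate such an effect from changes elsewhere in the structure.

The compounds shown leave open what the second stereo element contributes and why this one change moves the half-life. They also leave open whether a step of this size would recur with an amine or a carboxylic acid on the saturated chain.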